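A methoxyphenyl swap, from compound 3 to compound 4

The compounds below may be only part of what the source reports. "The series", "measured", "known", "first", "only" and "open" are said of these compounds alone.

The measured compounds, in a functional assay on HPAC cells (Homo sapiens) for inhibition, read by MTT assay, with a stated time of 72 h; a higher number here means a weaker inhibitor of growth, a lower number a stronger inhibitor of growth:
compound 1, `O=S(=O)(NCCCNCc1ccc(C(F)(F)F)cc1)c1cc(C(F)(F)F)cc(C(F)(F)F)c1`, gives 2700 nM
compound 2, `O=S(=O)(NCCCNCc1ccc(Br)cc1)c1cc(C(F)(F)F)cc(C(F)(F)F)c1`, gives 2900 nM
compound 3, `COc1cccc(CNCCCNS(=O)(=O)c2cc(C(F)(F)F)cc(C(F)(F)F)c2)c1`, gives 2400 nM

Compound 3 has the lowest of the three numbers, but its distance from the others is small: the step of a 1.1-fold lower number from compound 1 to compound 3 (0.05 log units; within the scatter) and the step of a 1.2-fold lower number from compound 2 to compound 3 (0.08 log units; within the scatter) both lie within the scatter, as does the step of a 1.1-fold higher number from compound 1 to compound 2 (0.03 log units; within the scatter) between the two other compounds. No order among the three can be read from these values.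

Compound 4, `COc1ccccc1CNCCCNS(=O)(=O)c1cc(C(F)(F)F)cc(C(F)(F)F)c1`, has not been measured. Its difference from compound 3 is 2-methoxyphenyl in place of 3-methoxyphenyl on a saturated chain carbon bound to an amine nitrogen.

The two steps that bear on this change are the ones already made at the same place, from compound 1 and from compound 2 to compound 3, and both stayed within the scatter. Nothing in the data suggests that shifting the methoxy group within the same ring should behave differently. Compound 4 is therefore expected to show a 1.0-fold higher number from compound 3 to compound 4 (0.02 log units; within the scatter), no change beyond the scatter. The estimate for compound 4 is 2500 nM, with a range from 1200 nM to 5200 nM.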

Compound 4, concentration for 50% growth inhibition: 2400 nM
The estimate for compound 4 lay 1.0-fold (0.02 log units) above the measured number, and the stated range covers the measured number.
By their numbers in this assay, from the lowest: compounds 3, 4, 1 and 2 (each within the scatter of the next).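

In this assay, among these compounds, the methoxy group's move gives no change at the digits printed from compound 3 to compound 4 (within the scatter) and shows, for the first time, that a change of 3-methoxyphenyl to 2-methoxyphenyl on a saturated chain carbon bound to an amine nitrogen leaves the number where it was. The 2-methoxyphenyl group also gives a 1.2-fold lower number from compound 2 to compound 4 (0.08 log units; within the scatter) and a 1.1-fold lower number from compound 1 to compound 4 (0.05 log units; within the scatter) so that all four aryl groups shown at this place now lie within the scatter of one another. No supporting evidence accounts for these close values.

The compounds shown leave open whether a carboxylic acid or an amine on this phenyl ring, or a pyridine ring in its place, would move the number beyond the scatter. They also leave open whether a longer chain in the shared core would do so.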